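The source may report more compounds than this note shows. Statements on the series, on what has been measured and on what is new or still open speak of the compounds shown alone.

Measured so far in a functional assay on NCI60 cells (Homo sapiens) for cytotoxicity; a higher number here means a weaker inhibitor of growth, a lower number a stronger inhibitor of growth:

compound 1 `Cc1ccc2c(n1)C(=O)C=C(N1CC1)C2=O` — 513 nM
compound 2 `C=CCNC1=CC(=O)c2nc(-c3ccccc3)ccc2C1=O` — 1910 nM
compound 3 `COCCCNC1=CC(=O)c2nc(-c3ccccc3)ccc2C1=O` — 3550 nM

Compound 3 gives the highest number of the three. Its nearest neighbour is compound 2, and that gap is within the scatter; the furthest is compound 1, and that gap lies beyond the scatter. Within the data shown here, the one step measured inside the set, a 1.9-fold higher number from compound 2 to compound 3 (0.27 log units; within the scatter), is itself within the scatter and changes only the chain on the amine nitrogen.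

The next compound, compound 4 `O=C1C(N2CC2)=CC(=O)c2nc(-c3ccccc3)ccc21`, is reached from compound 3 by a single change: aziridin-1-yl in place of (3-methoxypropyl)amino on a double-bonded ring carbon. Among the measured compounds shown here, no measured step covers this exchange, so the expectation rests on what the values show. Compound 1 carries the same aziridin-1-yl group on a core that differs only in its other substituent and gives 513 nM, a lower number than compound 3. Compounds 2 and 3, both with an open-chain amino group, sit higher. The expected direction for compound 4 is therefore downward, toward compound 1, and the step is estimated as a 5.5-fold lower number from compound 3 to compound 4 (0.74 log units; beyond the scatter). For compound 4 in this assay the estimate is 650 nM, with a range from 200 nM to 2000 nM.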

Compound 4, concentration for 50% growth inhibition: 27.5 nM
For compound 4 the middle estimate is 24-fold (1.37 log units) above the measured one; measured number outside the range, below it.
By their numbers in this assay, from the lowest: compound 4; then compound 1; then compounds 2 and 3 (each within the scatter of the next).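

Working notes on the series. In this assay, aziridin-1-yl on the double-bonded ring carbon separates sharply from the open-chain amino groups on the shared core: replacing (3-methoxypropyl)amino gives a large step (a 130-fold lower number from compound 3 to compound 4 (2.11 log units; beyond the scatter)), and replacing allylamino gives another (a 69-fold lower number from compound 2 to compound 4 (1.84 log units; beyond the scatter)), whereas the change between those two chains stayed within the scatter. With aziridin-1-yl held constant, the aromatic carbon also proves to be a sensitive place, as phenyl in place of methyl gives a further large step (a 19-fold lower number from compound 1 to compound 4 (1.27 log units; beyond the scatter)), so the low number depends on both places and not on the aziridin-1-yl group alone. No measured evidence bears on why either exchange has so large an effect.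

As far as these compounds go, whether the three-membered ring itself is required remains open, since azetidin-1-yl, pyrrolidin-1-yl or dimethylamino on the same ring carbon would be needed to test it. From the compounds shown here alone, it is also open whether phenyl would produce a comparable step alongside an open-chain amino group, and whether a pyridyl or 4-fluorophenyl group on the aromatic carbon would keep the number as low.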